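Swapping the aryl ketone in a nitrophenyl piperazine series

The source may hold more compounds than are shown below. What is called first, only, known or untested is meant among the compounds shown, and "the series" means these compounds.

Measured so far:
compound 1 `COc1ccc(C(=O)CCN2CCN(c3ccc([N+](=O)[O-])cc3)CC2)cc1`: 587000 nM
compound 2 `COc1ccc(C(=O)CCN2CCN(c3ccc([N+](=O)[O-])cc3)CC2)cc1OC`: 105000 nM

Compound 1 gives the highest of the two numbers in an ADME assay on Vero cells (Chlorocebus sabaeus) for cytotoxicity, read by resazurin assay, with a stated time of 72 h; a lower number here means a stronger inhibitor, a higher number a weaker inhibitor. Its nearest neighbour is compound 2, and the step of a 5.6-fold lower number from compound 1 to compound 2 (0.75 log units; beyond the scatter) is beyond the scatter. Compound 3 `O=C(CCN1CCN(c2ccc([N+](=O)[O-])cc2)CC1)c1ccc(Cl)c(F)c1` has not yet been measured in this assay. It differs from compound 1 as follows: 4-chloro-3-fluorophenyl in place of 4-methoxyphenyl on a carbonyl carbon. Within the data shown here, no measured step bears directly on this change; the only step, from compound 1 to compound 2, adds a methoxy on an aromatic carbon and does not exchange the ring itself, so it offers no guide in either direction. The expected step is therefore small and uncertain, a 2.0-fold lower number from compound 1 to compound 3 (0.29 log units; within the scatter), with a wide range. The estimate for compound 3 in this assay is 300000 nM, between 80000 nM and 1200000 nM.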

Compound 3, half-maximal inhibitory concentration: 89200 nM
The estimate for compound 3 lay 3.4-fold (0.53 log units) above the measured number, and the stated range covers the measured number.
By their numbers in this assay, from the lowest: compounds 3 and 2 (each within the scatter of the next); then compound 1.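

In this assay, the step of a 6.6-fold lower number from compound 1 to compound 3 (0.82 log units; beyond the scatter) shows that this position on the carbonyl carbon takes more than an added methoxy: the 4-methoxyphenyl can be exchanged outright for 4-chloro-3-fluorophenyl, which has no oxygen, and the number still falls beyond the scatter. Two different changes to the 4-methoxyphenyl of compound 1 now both give lower numbers, and compound 2 and compound 3 lie within the scatter of each other. Nothing available explains why either change lowers the number.

The compounds shown leave open whether the chlorine or the fluorine carries the step, since the two enter together. They also leave open how a plain phenyl, a pyridine ring or a carboxylic acid on the ring would read at this position, and what a longer chain would do.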